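Para-methyl added to the phenyl ketone of compound 2

A few compounds are considered here, and "the series" means these few. Any claim that something is new, unique, unknown or untested is made for them only; others in the source may bear on it.

Measured so far:
Compound 1, `Cc1ccc(C(=O)CSc2nnc(C)n2N2C(=O)c3ccccc3C2=O)cc1`: > 200000 nM in this assay, a limit and not a number.
Compound 2, `CCc1nnc(SCC(=O)c2ccccc2)n1N1C(=O)c2ccccc2C1=O`: > 200000 nM in this assay, a limit and not a number.

Both measured compounds were tested in a functional assay on MKN-45 cells (Homo sapiens) for cytotoxicity, read by MTT assay, with a stated time of 48 h; on this read-out higher numbers stand for weaker inhibition and lower numbers for stronger inhibition. Compound 2 stands at a limit of that assay, so its true value is not known as a number. The same is true of compound 1, whose reading is likewise a limit. Within the data shown here, the whole measured set therefore rests on (the limit of > 200000 nM in this assay, at which 2 of the 2 values shown sit), and no measured step between two numbers exists.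

Compound 3, `CCc1nnc(SCC(=O)c2ccc(C)cc2)n1N1C(=O)c2ccccc2C1=O`, differs from compound 2 by a single change: methyl in place of hydrogen on an aromatic carbon. Because the limit of > 200000 nM in this assay, at which 2 of the 2 values shown sit, holds for every reading shown, there is no basis for expecting this change to move the read-out beyond the scatter in either direction. The step that the limit leaves unreadable from compound 2 to compound 3 is expected to be none beyond the scatter, and most likely compound 3 will again return only a limit. If a number does appear, compound 3 is expected to give 300000 nM, with a range from 120000 nM to 1000000 nM.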

Compound 3, half-maximal inhibitory concentration: > 200000 nM
Compound 3 gave a limit, no number; the forecaster's own chance of this, stated with the estimate: 85%; the middle value does not contradict the limit.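

In this assay compound 3 gives > 200000 nM, a limit and not a number. No step to compound 3 can be read from either compound 2 or compound 1, since the whole set sits at one limit: the limit of > 200000 nM in this assay, at which 3 of the 3 values shown sit.

The compounds shown leave open how strongly any of them acts on these cells and whether either methyl change alters that.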